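The source may report more compounds than this note shows. Statements on the series, on what has been measured and on what is new or still open speak of the compounds shown alone.

Measured so far:
Compound 1 `CN(C)Cc1ccc2nc(NC(=O)N/N=C/c3cn(Cc4ccc(C(C)(C)C)cc4)c4ccccc34)sc2c1`: 2230 nM
Compound 2 `CCN(CC)Cc1ccc2nc(NC(=O)N/N=C/c3cn(Cc4ccc(Cl)cc4)c4ccccc34)sc2c1`: 2570 nM

Both compounds were tested in a functional assay on MDA-MB-231 cells (Homo sapiens) for cytotoxicity, read by MTT assay, with a stated time of 72 h; a higher number here means a weaker inhibitor, a lower number a stronger inhibitor. Compound 2, at 2570 nM, sits within the usual scatter of compound 1, so the two numbers cannot be told apart. The next compound to be measured is compound 3 `CN(C)Cc1ccc2nc(NC(=O)N/N=C/c3cn(Cc4ccc(Cl)cc4)c4ccccc34)sc2c1`. It keeps compound 2 unchanged except for one group: dimethylamino in place of diethylamino on a saturated chain carbon bound to an aromatic carbon. Going by the values given here, no measured pair isolates this change. Among the compounds with values here, the only hint is that compound 1 also carries dimethylamino, though it differs elsewhere too, and it gives 2230 nM. No shift beyond the scatter is therefore expected in this assay, in either direction. The expected change is a 1.1-fold lower number from compound 2 to compound 3 (0.05 log units; within the scatter). The estimated value for compound 3 is 2300 nM, with an expected range of 1000 nM to 5000 nM.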

Compound 3, half-maximal inhibitory concentration: 880 nM
For compound 3 the middle estimate is 2.6-fold (0.42 log units) above the measured one; measured number below the stated range.
By their numbers in this assay, from the lowest: compound 3; then compounds 1 and 2 (each within the scatter of the next).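

In this assay, with chloro held in place, dimethylamino in place of diethylamino on a saturated chain carbon bound to an aromatic carbon gives a 2.9-fold lower number from compound 2 to compound 3 (0.47 log units; beyond the scatter) and shows that the number responds to this amine. With dimethylamino held in place, chloro in place of tert-butyl on an aromatic carbon gives a 2.5-fold lower number from compound 1 to compound 3 (0.40 log units; beyond the scatter) in the same direction, a single-place effect that compounds 1 and 2, which differ in both places, could not reveal. Nothing at hand explains why either change lowers the number.

From the compounds shown here alone, whether a ring amine such as pyrrolidine or morpholine on the chain carbon would lower the number further remains open. So does the outcome with fluoro or methoxy in place of chloro on the aromatic carbon.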